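A few compounds are considered here, and "the series" means these few. Any claim that something is new, unique, unknown or untested is made for them only; others in the source may bear on it.

Measured compounds:
- compound 1 `Cc1ccc2[nH]c(=O)c(CN(Cc3ccc(O)cc3)Cc3ccc(C(C)(C)C)cc3)cc2c1`: 4900 nM
- compound 2 `Cc1ccc2[nH]c(=O)c(CN(Cc3ccc(C(C)(C)C)cc3)[C@@H](C)c3ccc(F)cc3)cc2c1`: > 5000 nM

In a toxicity assay on MDCK cells (Canis lupus familiaris) for cytotoxicity, read by crystal violet staining, with a stated time of 48 h (on this read-out lower numbers stand for higher toxicity in this test and higher numbers for lower toxicity in this test), compound 1 gives 4900 nM. Compound 2 reaches only the assay limit, > 5000 nM, so for compound 2 a limit and not a number is known. On the two numbers shown compound 2 therefore sits at the low-toxicity end, and the step of an at least 1.0-fold higher number from compound 1 to compound 2 (0.00 log units; that floor lies within the scatter) is bounded only by that limit (the limit of > 5000 nM in this assay, at which 1 of the 2 values shown sits). Compound 3 `Cc1ccc2[nH]c(=O)c(CN(Cc3ccc(C(C)(C)C)cc3)C(C)c3ccc(OC(F)F)cc3)cc2c1` differs from compound 2 by 1-(4-(difluoromethoxy)phenyl)ethyl in place of 1-(4-fluorophenyl)ethyl on an amine nitrogen. Going by the values given here, the single measured step, from compound 1 to compound 2, swapped a different group on the same nitrogen and did not move beyond the limit, so it gives no sign of a change beyond the scatter; no further step bears on this change. Compound 3 is expected to stay near compound 2, a step that the limit leaves unreadable from compound 2 to compound 3. The estimate for compound 3 in this assay is 5500 nM, expected between 2500 nM and 12000 nM, most likely again reported only as a limit.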

Compound 3, half-maximal cytotoxic concentration: > 5000 nM
Compound 3: no number, only a limit (the forecaster's own chance of this, stated with the estimate: 70%); the middle value is on the limit's open side.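

In this assay compound 3 gives > 5000 nM, which is a limit and not a number, so 1-(4-(difluoromethoxy)phenyl)ethyl on the amine nitrogen shows no sign of higher toxicity in this test. Replacing 4-hydroxybenzyl with this group gives an at least 1.0-fold higher number from compound 1 to compound 3 (0.00 log units; that floor lies within the scatter), so a second group at this place also shows no change beyond the scatter. The step between the two groups on the ethyl-linked ring cannot be read, because compound 2 and compound 3 both stop at a limit: the limit of > 5000 nM in this assay, at which 2 of the 3 values shown sit.

Going by these compounds, how far compound 2 and compound 3 lie beyond that limit stays open. So does whether an amine or a carboxylic acid in place of the difluoromethoxy group would bring the number down to a measurable value.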